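A few compounds are considered here, and "the series" means these few. Any claim that something is new, unique, unknown or untested is made for them only; others in the source may bear on it.

Measured in a physicochemical assay for solubility, read by spectrophotometry, in phosphate buffer, with a stated time of 18 h, at pH 7.4; on this read-out lower numbers stand for lower solubility and higher numbers for higher solubility:
- compound 1 `CCc1ccc(-c2nc3c(c(C)nn3-c3ccccc3)c(-c3ccccc3O)c2C#N)cc1`: 3100 nM
- compound 2 `CCc1ccc(-c2nc3c(c(C)nn3-c3ccccc3)c(-c3ccccc3S(C)(=O)=O)c2C#N)cc1`: 2200 nM

Among the measured compounds shown here, only two numbers exist so far, and compound 1 stands within the scatter of compound 2. They differ by methylsulfonyl in place of hydroxy on an aromatic carbon.

Compound 3 `Cc1cccc(-c2nc3c(c(C)nn3-c3ccccc3)c(-c3ccccc3O)c2C#N)c1` keeps the 2-hydroxyphenyl group of compound 1 and changes a different group, with 3-methylphenyl in place of 4-ethylphenyl on an aromatic carbon. The exchanged group sits next to the ring nitrogen and ortho to a cyano group. For the measured compounds named here, no measured step covers a change at this place, so the series gives no direct size for it.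

Going by the values given here, the only guide is indirect: the single measured step, a 1.4-fold lower number from compound 1 to compound 2 (0.15 log units; within the scatter), did not leave the scatter. On that basis, no step beyond the scatter is expected in this assay, and no direction is favoured. The expected step is a 1.1-fold higher number from compound 1 to compound 3 (0.04 log units; within the scatter). The estimate for compound 3 is 3400 nM, with an expected range of 1500 nM to 7500 nM.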

Compound 3, solubility: 42000 nM
Compound 3: middle estimate off by 12-fold (1.09 log units), on the low side; measured number outside the range, above it.
By their numbers in this assay, from the lowest: compounds 2 and 1 (each within the scatter of the next); then compound 3.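

In this assay, the place next to the ring nitrogen and ortho to a cyano group turns out to be sensitive: with the 2-hydroxyphenyl group kept, 3-methylphenyl in place of 4-ethylphenyl gives a 14-fold higher number from compound 1 to compound 3 (1.13 log units; beyond the scatter), whereas the earlier exchange of hydroxy for methylsulfonyl gave only a 1.4-fold lower number from compound 1 to compound 2 (0.15 log units; within the scatter). Among the compounds shown here, of the two places varied so far, this is the only one with a step beyond the scatter, even though the exchange is modest by the count, with 8 heavy atoms leaving, 7 entering, and hydrogen-bond donors and acceptors absent from both groups. Nothing available here bears on what lies behind this large step.

The exchange alters both the length of the alkyl chain and its place on the phenyl ring, and the compounds shown do not separate these two changes. Also open, on these data alone, are what an unsubstituted phenyl or a phenyl carrying an amine would give at this place, and whether the step would carry over to the methylsulfonyl group of compound 2.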